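Thiosemicarbazones with a cyclohexyl amide: moving to compound 4

The source may hold more compounds than are shown below. What is called first, only, known or untested is meant among the compounds shown, and "the series" means these compounds.

Measured compounds in a functional assay on MDA-MB-231 cells (Homo sapiens) for inhibition, read by WST assay, with a stated time of 48 h; on this read-out lower numbers stand for stronger inhibition and higher numbers for weaker inhibition:
- compound 1 `O=[N+]([O-])c1cccc(/C=N\NC(=S)NC2CCCCC2)c1` gives 84800 nM
- compound 2 `S=C(N/N=C\c1ccc(Cl)cc1)NC1CCCCC1` gives 38300 nM
- compound 3 `O=[N+]([O-])c1ccccc1/C=N\NC(=S)NC1CCCCC1` gives 118000 nM

All three share one core, differing only in the substituent on the aromatic ring attached to the imine carbon. Compound 2 stands lowest of the three numbers in this assay; compound 1 lies closest to it, at a number beyond the scatter, and compound 3 lies furthest, also beyond the scatter. The whole series sits at weak inhibition.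

Compound 4 `CCOc1ccc(/C=N\NC(=S)NC2CCCCC2)cc1` is not yet measured. It differs from compound 2 in one place: ethoxy in place of chloro on an aromatic carbon. Within the data shown here, no step between measured compounds follows this kind of change, so there is no direct reference. The measured numbers span a narrow band of weak inhibition, and a single change on the ring gives no reason to expect a departure from it. The expectation for a 1.4-fold higher number from compound 2 to compound 4 (0.16 log units; within the scatter) is therefore a step of no more than modest size, if any beyond the scatter, most likely towards a somewhat higher number. Compound 4 is expected to give about 55000 nM in this assay, within a range from 20000 nM to 140000 nM.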

Compound 4, half-maximal inhibitory concentration: 68200 nM
The estimate for compound 4 lay 1.2-fold (0.09 log units) below the measured number; low and high end bracket the measured number.
By their numbers in this assay, from the lowest: compounds 2, 4, 1 and 3 (each within the scatter of the next, the first and the last beyond it).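

In this assay, the aromatic carbon para to a large group now has its first step between measured compounds: ethoxy in place of chloro gives a 1.8-fold higher number from compound 2 to compound 4 (0.25 log units; within the scatter). At this place, a group of 3 heavy atoms with 1 hydrogen-bond acceptor can therefore stand in for a single chlorine with no separation beyond the scatter, and the read-out stays in the weak band of the series. Nothing measured here accounts for the two groups reading alike.

The compounds shown leave open whether any group on this aromatic carbon can separate from chloro and ethoxy beyond the scatter; an amine or a carboxylic acid at the same place would put that to the test. Also open, from the compounds shown here alone, is what the cyclohexyl group shared by all four compounds contributes to the read-out, a question that a longer open chain such as hexyl in its place, with the chloro or ethoxy group held fixed, would address.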